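The source may report more compounds than this note shows. Statements on the series, on what has been measured and on what is new or still open speak of the compounds shown alone.

Measured compounds in an ADME assay on MT4 cells (Homo sapiens) for cytotoxicity, read by MTT assay, with a stated time of 5 days; a higher number here means that more compound is tolerated, a lower number that less compound is tolerated:

Compound 1 `Cc1cc(C#N)cc(C)c1Oc1ccnc(Nc2ccc(CN3CCC(NC(=O)OC(C)(C)C)CC3)cc2)n1`: 4340 nM
Compound 2 `Cc1cc(C#N)cc(C)c1Oc1ccnc(Nc2ccc(CNC3CCN(C(=O)OC(C)(C)C)CC3)cc2)n1`: 3510 nM
Compound 3 `Cc1cc(C#N)cc(C)c1Oc1ccnc(Nc2ccc(CN3CCN(S(C)(=O)=O)CC3)cc2)n1`: 3430 nM

On the numbers alone compound 1 sits at the top of the three, but its gaps to compound 2 and to compound 3 both lie within the usual scatter, so the three compounds read as a single level in this assay and no ordering among them is claimed. Within the data shown here, no paired step between measured compounds is available here.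

Compound 4 `Cc1cc(C#N)cc(C)c1Oc1ccnc(Nc2ccc(CN3CCC(NS(C)(=O)=O)CC3)cc2)n1` is not yet measured. It differs from compound 1 by methylsulfonyl in place of tert-butoxycarbonyl on an amine nitrogen. Compound 3, which carries a methylsulfonyl on a different amine nitrogen, sits at 3430 nM, within the scatter of compound 1, and compound 2 with the tert-butoxycarbonyl moved to the ring nitrogen sits at 3510 nM, also within the scatter. Nothing among these three points to a step beyond the scatter for the exchange in question. The expected step of a 1.1-fold lower number from compound 1 to compound 4 (0.06 log units; within the scatter) is therefore set as none beyond the scatter. For compound 4 the estimate in this assay is 3800 nM, with an expected range from 1800 nM to 8000 nM.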

Compound 4, half-maximal cytotoxic concentration: 18100 nM
Compound 4: the middle estimate sits 4.8-fold (0.68 log units) below what was measured; measured number above the stated range.
By their numbers in this assay, from the lowest: compounds 3, 2 and 1 (each within the scatter of the next); then compound 4.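

In this assay, methylsulfonyl in place of tert-butoxycarbonyl on an amine nitrogen whose other neighbour is a saturated ring carbon gives a 4.2-fold higher number from compound 1 to compound 4 (0.62 log units; beyond the scatter), the first separation in a series whose earlier members stood at a single level. Methylsulfonyl alone does not set this level: 4-(methanesulfonamido)piperidin-1-yl in place of 4-(methylsulfonyl)piperazin-1-yl gives a 5.3-fold higher number from compound 3 to compound 4 (0.72 log units; beyond the scatter), so in these two compounds the surroundings of the group matter as well. No evidence at hand accounts for either step.

As far as these compounds go, whether the higher number is specific to methanesulfonamido stays open; an acetyl group, a free amine or a longer chain on the sulfonyl at the same nitrogen would test this. From the compounds shown here alone, how far the step carries to a change elsewhere on the core also remains open.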